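From an Aminophenyl to a Dimethylphenyl Substituent

The source may hold more compounds than are shown below. What is called first, only, known or untested is meant among the compounds shown, and "the series" means these compounds.

Of the compounds shown here, three built on a shared core have been tested in a functional assay on HCT-116 cells (Homo sapiens) for antiproliferative activity, read by MTT assay, with a stated time of 48 h; a lower number here means a stronger inhibitor, a higher number a weaker inhibitor. Compound 1 `COc1ccccc1-n1nncc1CN1C(=O)C2(C(C#N)=C(N)Oc3c2c2nc4ccccc4nc2c2ccccc32)c2ccccc21` carries a 2-methoxyphenyl group on the aromatic nitrogen, and in this assay compound 1 gives > 50000 nM, which is a limit of the assay rather than a number. Compound 2 `CCOc1ccccc1-n1nncc1CN1C(=O)C2(C(C#N)=C(N)Oc3c2c2nc4ccccc4nc2c2ccccc32)c2ccccc21` bears a 2-ethoxyphenyl group in that place, and in this assay compound 2 gives > 50000 nM, again a limit. Among the measured compounds shown here, compound 3 `N#CC1=C(N)Oc2c(c3nc4ccccc4nc3c3ccccc23)C12C(=O)N(Cc1cnnn1-c1ccc(N)cc1)c1ccccc12` carries a 4-aminophenyl group, and in this assay compound 3 gives 45200 nM, the only number among the three values, the other two sitting at the limit of > 50000 nM in this assay, at which 2 of the 3 values shown sit. The step that the two limits leave unreadable from compound 1 to compound 2 cannot be read. The steps of an at least 1.1-fold lower number from compound 1 to compound 3 (0.04 log units; that floor lies within the scatter) and an at least 1.1-fold lower number from compound 2 to compound 3 (0.04 log units; that floor lies within the scatter) have floors that lie within the scatter, so they settle nothing about the aryl group.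

Compound 4 `Cc1ccc(-n2nncc2CN2C(=O)C3(C(C#N)=C(N)Oc4c3c3nc5ccccc5nc3c3ccccc43)c3ccccc32)cc1C` differs from compound 3 by 3,4-dimethylphenyl in place of 4-aminophenyl on an aromatic nitrogen. The two measured steps that touch this position are both unreadable beyond their floors, so no step beyond the scatter is expected in this assay in either direction. For compound 4 the expected step is a 1.2-fold higher number from compound 3 to compound 4 (0.09 log units; within the scatter). In this assay compound 4 is estimated at 55000 nM, within 25000 nM to 150000 nM, with a substantial chance that only a limit is reported.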

Compound 4, half-maximal inhibitory concentration: > 50000 nM
Compound 4 was reported as a limit (the forecaster's own chance of this, stated with the estimate: 65%); the middle value lies beyond the limit too.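

In this assay compound 4 gives > 50000 nM, which is a limit of the assay and not a number. Against the only number in the series, the change gives an at least 1.1-fold higher number from compound 3 to compound 4 (0.04 log units; that floor lies within the scatter), while the steps to compound 4 from compound 1 and from compound 2 cannot be read. The 3,4-dimethylphenyl group thus stands with the 2-methoxyphenyl and 2-ethoxyphenyl groups at a single ceiling, and compound 3 remains the only compound with a number: the limit of > 50000 nM in this assay, at which 3 of the 4 values shown sit.

The compounds shown leave open whether the 4-aminophenyl group differs at all from the other aryl groups on this aromatic nitrogen, since every readable step to compound 3 or from it has a floor within the scatter. They also leave open whether any other group in this place, such as a phenyl ring carrying a carboxylic acid or a hydroxyl, or a longer chain in place of the ring, would give a value well clear of this limit.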